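A few compounds are considered here, and "the series" means these few. Any claim that something is new, unique, unknown or untested is made for them only; others in the source may bear on it.

Compound 1 `Cc1ccc2oc(-c3cccc(Br)c3)cc2c1`: in an assay on cells for inhibition of Amine oxidase [flavin-containing] A (Homo sapiens), read by fluorescence and Amplex Red, with a stated time of 15 min (a higher number here means a weaker inhibitor, a lower number a stronger inhibitor), compound 1 returns only the limit > 100000 nM.
Compound 2 `Cc1cccc2cc(-c3ccc(Br)cc3)oc12`: in this assay compound 2 gives 100000 nM.
Compound 3 `Cc1ccc2oc(-c3ccccc3)cc2c1`: in this assay compound 3 returns only the limit > 100000 nM.

Within the data shown here, compound 1 therefore stands at the limit of this assay, without a number of its own; two of the three values sit there the limit of > 100000 nM in this assay, at which 2 of the 3 values shown sit, and the single numeric value, that of compound 2, is at the same figure. Among the measured compounds shown here, the one measured step, a step that the two limits leave unreadable from compound 1 to compound 3, runs between two limits and its size cannot be read.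

Compound 4 `Brc1cccc(-c2cc3ccccc3o2)c1` differs from compound 1 by hydrogen in place of methyl on an aromatic carbon. For the measured compounds named here, no measured pair shows this change, and the only measured step, a step that the two limits leave unreadable from compound 1 to compound 3, gives no readable size to carry over. Nothing in these data points to movement beyond the scatter in either direction, and the most likely outcome is that compound 4 also returns only a limit. Compound 4 is therefore estimated at 100000 nM, with a range from 30000 nM to 300000 nM. The expected step of a number no higher from compound 1 to compound 4 (the limit leaves the size open) is none beyond the scatter.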

Compound 4, half-maximal inhibitory concentration: 100000 nM
The estimate for compound 4 equals the measured number at the digits printed; measured number inside the range.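

Compound 4 carries hydrogen in place of the methyl on an aromatic carbon of the core of compound 1. In this assay compound 4 gives 100000 nM. Compound 1 returns only a limit, > 100000 nM. The change gives a number no higher from compound 1 to compound 4 (the limit leaves the size open), but removing the methyl at this position does not bring compound 4 clear of the edge of what the assay reads, where the series stays: the limit of > 100000 nM in this assay, at which 2 of the 4 values shown sit.

Still open, as far as these compounds go, is whether an amine or a carboxylic acid, set in place of the methyl or the bromo, would give a value clear of that edge. Also open, from the compounds shown here alone, is any ranking, as no value shown here stands away from that edge.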